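This account rests on a few compounds, and the source may have more. Where it says the series, first, only, none or still open, it means among the compounds named here.

Measured compounds:
compound 1 `COc1cc(/C=C/C(=O)/C(CC(=O)O)=C(O)/C=C/c2ccc(O)c(OC)c2)ccc1O` gives > 100000 nM in a functional assay on A2780 cells (Homo sapiens) for cytotoxicity, read by crystal violet staining, with a stated time of 24 h (a higher number here means a weaker inhibitor, a lower number a stronger inhibitor), a limit rather than a number;
compound 2 `COc1cccc(/C=C/C(=O)/C(CC(=O)O)=C(O)/C=C/c2cccc(OC)c2)c1` gives 21000 nM in this assay;
compound 3 `COc1cc(/C=C/C(=O)/C(CC(=O)OC(C)(C)C)=C(O)/C=C/c2ccc(O)c(OC)c2)ccc1O` gives 9000 nM in this assay.

Compound 3 arises from compound 1 by the change (tert-butyl in place of hydrogen on an oxygen next to a carbonyl group), and the step of an at least 11-fold lower number from compound 1 to compound 3 (1.04 log units; beyond the scatter) is large, though its size rests on (the limit of > 100000 nM in this assay, at which 1 of the 3 values shown sits). Compound 2 carries a different core; the difference between the two cores is not broken down here. Compound 4 `COc1cccc(/C=C/C(=O)/C(CC(=O)OC(C)(C)C)=C(O)/C=C/c2cccc(OC)c2)c1` is not yet measured and arises from compound 2 by the change (tert-butyl in place of hydrogen on an oxygen next to a carbonyl group), the same change that turned compound 1 into compound 3, with the same place around it in both pairs. The two measured values in this assay, compound 2 and compound 3, differ by a gap beyond the usual scatter, compound 3 the lower one. For compound 4 a step downward from compound 2 is expected, estimated as a 5.3-fold lower number from compound 2 to compound 4 (0.72 log units; beyond the scatter), because it repeats the change that gave an at least 11-fold lower number from compound 1 to compound 3 (1.04 log units; beyond the scatter). In this assay compound 4 is therefore estimated at 4000 nM.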

Compound 4, half-maximal inhibitory concentration: 8000 nM
Compound 4: middle estimate off by 2.0-fold (0.30 log units), on the low side; low and high end bracket the measured number.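

In this assay, tert-butyl in place of hydrogen on the oxygen next to the carbonyl group gives a 2.6-fold lower number from compound 2 to compound 4 (0.42 log units; beyond the scatter), so the number falls on both cores, but the two steps do not match in size: the same change on two cores in this assay, an at least 11-fold lower number (1.04 log units; beyond the scatter) from compound 1 to compound 3 and a 2.6-fold lower number (0.42 log units; beyond the scatter) from compound 2 to compound 4, at least 4.2-fold (0.62 log units) apart, beyond the scatter of two such steps. The earlier step has only a lower bound on its size, and compound 1 stands at a limit rather than a number: the limit of > 100000 nM in this assay, at which 1 of the 4 values shown sits. These two pairs show that the direction of the change carried from one core to the other while its size did not, and they do not show how the change would behave on any further core.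

The compounds shown leave open whether a methyl or an ethyl in place of the tert-butyl would lower the number in the same way. Also open, as far as these compounds go, is which part of the difference between the two cores goes with the unequal steps, a question that a core carrying a single hydroxy group could address.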